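Adding a Chloro to a Weak Bromo Compound

A few compounds are considered here, and "the series" means these few. Any claim that something is new, unique, unknown or untested is made for them only; others in the source may bear on it.

In a functional assay on KB cells (Homo sapiens) for inhibition (a lower number here means a stronger inhibitor, a higher number a weaker inhibitor), compound 3 `Clc1cc2nc(Br)n(Cc3ccccc3)c2cc1Cl` gives > 100000 nM, which is a limit of the assay and not a number. Compound 1 `Clc1cc2nc(Cl)n(Cc3ccccc3)c2cc1Cl` gives > 100000 nM, also only a limit. Compound 2 `Clc1cc2nc(Cl)n(Cc3ccccc3Cl)c2cc1Cl` does give a number, 156000 nM.

Compound 4 `Clc1cc2nc(Br)n(Cc3ccccc3Cl)c2cc1Cl` differs from compound 3 by a single change, chloro in place of hydrogen on an aromatic carbon. The same change appears in a step that the limit leaves unreadable from compound 1 to compound 2. The swap of chloro for bromo is a step that the two limits leave unreadable from compound 1 to compound 3. Neither size can be read because of the limit of > 100000 nM in this assay, at which 2 of the 3 values shown sit.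

The measured steps therefore fix no direction, and the best guide is compound 2 at 156000 nM, which carries the same added chloro. Only a small change is expected in this assay. The expected step is a step that the limit leaves unreadable from compound 3 to compound 4. For compound 4 the estimated value is 140000 nM, with an expected range from 60000 nM to 350000 nM. The assay may again report only a limit.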

Compound 4, half-maximal inhibitory concentration: 78000 nM
Compound 4: middle estimate off by 1.8-fold (0.25 log units), on the high side; the measured number falls inside the stated range.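

In this assay, the chloro added to the aromatic carbon can now be sized for the bromo compounds, though only as a floor: it gives an at least 1.2-fold lower number from compound 3 to compound 4 (0.10 log units; that floor lies within the scatter). The swap of chloro for bromo, unreadable before, can also now be read with that added chloro in place, as a 2.0-fold lower number from compound 2 to compound 4 (0.30 log units; within the scatter), so the two halogens on the shared core are not told apart here. The first of these steps remains only a floor because it starts from a limit: the limit of > 100000 nM in this assay, at which 2 of the 4 values shown sit.

As far as these compounds go, the true size of the step from adding the chloro therefore stays open, including whether it exceeds the usual scatter. Also open, from the compounds shown here alone, is how an amine or a methoxy group would read at this same place, ortho to a large group.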